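Estimating compound 3 from two measured neighbours

This account rests on a few compounds, and the source may have more. Where it says the series, first, only, none or still open, it means among the compounds named here.

Compound 1 `Cn1cc(C2=C(c3nn(CCn4ccnc4)c4ncccc34)C(=O)N(c3ccccc3)C2=O)c2ccccc21`: 8770 nM
Compound 2 `CN(C)CCCn1nc(C2=C(c3cn(C)c4ccccc34)C(=O)N(c3ccccc3)C2=O)c2cccnc21`: 5840 nM

Going by the values given here, in a functional assay on ECa-109 cells (Homo sapiens) for antiproliferative activity, read by MTT assay, with a stated time of 48 h (a higher number here means a weaker inhibitor, a lower number a stronger inhibitor), compound 2 cannot be separated from the only other measured compound. Compound 3 `Cn1cc(C2=C(c3nn(CCCCn4ccnc4)c4ncccc34)C(=O)N(c3ccccc3)C2=O)c2ccccc21` has not been measured and differs from compound 2 by (1H-imidazol-1-yl)methyl in place of dimethylamino on a saturated chain carbon, three bonds along the chain from an aromatic nitrogen. This turns 3-(dimethylamino)propyl into 4-(1H-imidazol-1-yl)butyl. Among the compounds with values here, one measured step bears on this, exchanging the same two kinds of group in the reverse sense: a 1.5-fold lower number from compound 1 to compound 2 (0.18 log units; within the scatter). Within the data shown here, on that single guide, no change beyond the scatter is expected, although the butyl chain has no measured precedent. The expected step is a 1.1-fold higher number from compound 2 to compound 3 (0.05 log units; within the scatter). The estimate for compound 3 is 6500 nM, with an expected range of 2500 nM to 16000 nM.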

Compound 3, half-maximal inhibitory concentration: 7540 nM
The estimate for compound 3 lay 1.2-fold (0.06 log units) below the measured number; measured number inside the range.
By their numbers in this assay, from the lowest: compounds 2, 3 and 1 (each within the scatter of the next).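

In this assay, lengthening the chain that ends in 1H-imidazol-1-yl gives a 1.2-fold lower number from compound 1 to compound 3 (0.07 log units; within the scatter) and so does not separate the two chain lengths. Placing 4-(1H-imidazol-1-yl)butyl where 3-(dimethylamino)propyl stood gives a 1.3-fold higher number from compound 2 to compound 3 (0.11 log units; within the scatter) and likewise does not separate the two groups, so neither chain length nor end group distinguishes these three compounds at this position. No supporting data explain this result.

As far as these compounds go, whether a morpholine or a carboxylic acid at the chain end, or a chain shorter than these, would stand apart from these compounds remains open.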